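Fluoro removal on the aryl piperazine of a succinimide amide

This account rests on a few compounds, and the source may have more. Where it says the series, first, only, none or still open, it means among the compounds named here.

Measured compounds and their values:
compound 1 `CCC(C(=O)N1CCN(c2cccc(F)c2)CC1)N1C(=O)CCC1=O` — 0%
compound 2 `CC(C(=O)N1CCN(c2cccc(F)c2)CC1)N1C(=O)CCC1=O` — 0%

In a functional assay on the whole organism (strain Swiss) with Mus musculus as the target, in the maximal electroshock model, with a stated time of 1 h, at a dose of 100 mg/kg by the intraperitoneal route (a higher number here means a stronger effect of the compound at the dose given, a lower number a weaker effect), compound 1 gives 0%, level with compound 2 at the digits shown, and the step of no change at the digits printed from compound 1 to compound 2 (within the scatter) lies within the scatter. Compound 3 `CCC(C(=O)N1CCN(c2ccccc2)CC1)N1C(=O)CCC1=O` is not yet measured. It differs from compound 1 by hydrogen in place of fluoro on an aromatic carbon; cut one bond further out, the change reads 3-fluorophenyl to phenyl. Going by the values given here, no measured step alters the aromatic ring, so the single step at hand, from compound 1 to compound 2 on the saturated chain carbon, bears on it only as a sign that the series so far shows no effect at this dose. The expectation for compound 3 is therefore a step of no change at the digits printed from compound 1 to compound 3 (within the scatter) of no size beyond the scatter in this assay. Compound 3 is estimated at 0%, within 0% to 20%.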

Compound 3, a percentage reported as activity, at one dose (the size of the read-out at that dose, not a potency): 0%
Compound 3: the middle estimate sits on the measured number at the digits printed; the range from low to high includes it.
By their numbers in this assay, from the lowest: compounds 1, 2 and 3 (each within the scatter of the next).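

In this assay, going by these compounds alone, the aromatic ring comes into play for the first time: 3-fluorophenyl to phenyl, hydrogen in place of fluoro on an aromatic carbon, gives no change at the digits printed from compound 1 to compound 3 (within the scatter), so the fluoro group is not by itself what separates these compounds at this dose. Since compound 1 and compound 3 both sit at the bottom of the read-out, this step says nothing on what the fluoro group would do in a compound with a measurable effect. No independent data bear on this result.

On these data alone, it remains open whether a trifluoromethyl group or an amine on the phenyl ring, or a longer chain on the saturated carbon, would give any effect in this assay. As far as these compounds go, a comparison of the phenyl and 3-fluorophenyl groups on an active member of the series also remains open.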